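Adding a Trifluoromethyl to the Fluorophenoxy Group

The source may report more compounds than this note shows. Statements on the series, on what has been measured and on what is new or still open speak of the compounds shown alone.

Compound 1 `CC(C)[C@H](NC(=O)COc1cccc2ccccc12)C(=O)N[C@@H](CC(=O)O)C(=O)COc1ccccc1F` gives 15700 nM.
Compound 2 `CC(C)[C@H](NC(=O)COc1cccc2ccccc12)C(=O)N[C@@H](CC(=O)O)C(=O)COc1c(F)c(F)c(-c2c(F)c(F)c(F)c(F)c2F)c(F)c1F` gives 40000 nM.

Both numbers come from a functional assay with Homo sapiens as the target; on this read-out lower numbers stand for stronger inhibition and higher numbers for weaker inhibition. Within the data shown here, of the two, compound 1 stands lowest, and compound 2 lies above it by a gap beyond the usual scatter; no single-change step links the two, so their values can only be set side by side. The unmeasured compound 3 `CC(C)[C@H](NC(=O)COc1cccc2ccccc12)C(=O)N[C@@H](CC(=O)O)C(=O)COc1cccc(C(F)(F)F)c1F` shares the core of compound 1 and differs from it in one place: trifluoromethyl in place of hydrogen on an aromatic carbon. Among the measured compounds shown here, there is no measured pair that shows what this change does in this assay, so the expectation rests on compound 1 alone. Compound 3 is expected to stay close to compound 1, with a small step from compound 1 to compound 3 a 1.3-fold higher number from compound 1 to compound 3 (0.11 log units; within the scatter) that may not exceed the scatter, in either direction. The estimate for compound 3 is 20000 nM, with a range from 6000 nM to 60000 nM.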

Compound 3, half-maximal inhibitory concentration: 18200 nM
Compound 3: middle estimate off by 1.1-fold (0.04 log units), on the high side, within the range that was stated.
By their numbers in this assay, from the lowest: compounds 1 and 3 (each within the scatter of the next); then compound 2.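

In this assay, among these compounds, the change from 2-fluorophenoxy to 2-fluoro-3-(trifluoromethyl)phenoxy gives a 1.2-fold higher number from compound 1 to compound 3 (0.06 log units; within the scatter) as the first single-change step. This aromatic carbon therefore takes a trifluoromethyl group, with its 4 heavy atoms in place of a hydrogen, without any difference that can be told apart from the scatter of repeated measurements. Nothing measured here bears on why the two numbers lie so close together.

The compounds shown leave open whether a methyl, a methoxy, a nitrile or an amine on this same carbon would also stay within the scatter. They also leave open what a trifluoromethyl group would do on the other carbons of this ring.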